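Methoxy to hydroxy on a shared core, both parents inactive

A few compounds are considered here, and "the series" means these few. Any claim that something is new, unique, unknown or untested is made for them only; others in the source may bear on it.

Compound 1 `O=C(Nc1cccc(-n2cc(-c3ccncc3)c(-c3ccc(Cl)c(O)c3)n2)c1)Nc1ccc(Cl)c(Cl)c1` and compound 2 `COc1cc(-c2nn(-c3cccc(NC(=O)Nc4ccc(Cl)c(C(F)(F)F)c4)c3)cc2-c2ccncc2)ccc1Cl` share a core and differ in two places. In a functional assay on RXF 393 cells (Homo sapiens) for inhibition, read by sulforhodamine B assay, with a stated time of 48 h (a lower number here means that less compound is tolerated, a higher number that more compound is tolerated), compound 1 gives only a limit of > 32500 nM. Compound 2 likewise reaches only a limit of > 32500 nM in this assay. Both readings thus sit at the limit of > 32500 nM in this assay, at which 2 of the 2 values shown sit. Compound 3 `O=C(Nc1cccc(-n2cc(-c3ccncc3)c(-c3ccc(Cl)c(O)c3)n2)c1)Nc1ccc(Cl)c(C(F)(F)F)c1` carries hydrogen in place of methyl on an oxygen on an aromatic ring. For the measured compounds named here, no step between measured compounds is available, so the step is expected to be none beyond the scatter, estimated as a step that the limit leaves unreadable from compound 2 to compound 3. Compound 3 is therefore expected to give about 40000 nM, most likely again only a limit, with a range from 15000 nM to 100000 nM.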

Compound 3, concentration lethal to 50% of the cells: > 32500 nM
Compound 3 was reported as a limit; the forecaster's own chance of this, stated with the estimate: 80%; the middle value lies beyond the limit too.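

No step can be read from compound 2 to compound 3 or from compound 1 to compound 3, since each compound gives only a limit in this assay: the limit of > 32500 nM in this assay, at which 3 of the 3 values shown sit. The compounds shown leave open whether methoxy to hydroxy, or trifluoromethyl in place of chloro, changes the reading at all.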